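Swapping the aromatic group on a double-bonded chain carbon

The compounds below may be only part of what the source reports. "The series", "measured", "known", "first", "only" and "open" are said of these compounds alone.

In a functional assay on HepG2 cells (Homo sapiens) for cytotoxicity, read by MTT assay, with a stated time of 48 h (a lower number here means a stronger inhibitor, a higher number a weaker inhibitor), compound 1 `O=C1/C(=C\c2ccc(O)cc2)S/C(=N/c2ccccc2)N1Cc1ccncc1` gives 11800 nM, compound 2 `COc1ccc(/C=C2/S/C(=N/c3ccccc3)N(Cc3ccncc3)C2=O)cc1` gives 19100 nM and compound 3 `COc1ccc(/C=C2/S/C(=N/c3ccccc3)N(Cc3ccncc3)C2=O)cc1OC` gives 28900 nM. Compound 3 therefore lies within the scatter of compound 2 but beyond it from compound 1. Compound 4 `O=C1/C(=C\c2cccc(Cl)c2)S/C(=N/c2ccccc2)N1Cc1ccncc1` changes the group at the same place: 3-chlorophenyl in place of 3,4-dimethoxyphenyl on a double-bonded chain carbon bound to a double-bonded ring carbon. Three measured changes to this group bear on it: a 1.6-fold higher number from compound 1 to compound 2 (0.21 log units; within the scatter), a 1.5-fold higher number from compound 2 to compound 3 (0.18 log units; within the scatter) and a 2.4-fold higher number from compound 1 to compound 3 (0.39 log units; beyond the scatter). For the measured compounds named here, none of the measured compounds carries 3-chlorophenyl, so this evidence is indirect. These steps are small, so no step beyond the scatter is expected. The estimate is a 1.6-fold lower number from compound 3 to compound 4 (0.21 log units; within the scatter). For compound 4, the expected value is 18000 nM, with an estimated range of 7000 nM to 45000 nM.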

Compound 4, half-maximal inhibitory concentration: 28900 nM
Beside the measured number, compound 4's estimate is 1.6-fold (0.21 log units) below it, within the range that was stated.
By their numbers in this assay, from the lowest: compounds 1, 2, 3 and 4 (each within the scatter of the next, the first and the last beyond it).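

In this assay, 3-chlorophenyl on this double-bonded chain carbon reads much like the oxygen-bearing rings: there is no change at the digits printed from compound 3 to compound 4 (within the scatter) and a 1.5-fold higher number from compound 2 to compound 4 (0.18 log units; within the scatter). Only the comparison with the 4-hydroxyphenyl group goes beyond the scatter, with a 2.4-fold higher number from compound 1 to compound 4 (0.39 log units; beyond the scatter), so a chlorine-bearing ring without hydrogen-bond acceptors fits the same narrow band as 3,4-dimethoxyphenyl. Nothing available explains why these numbers stay so close. Going by these compounds, whether an aromatic ring carrying an amine or a carboxylic acid, or a plain alkyl chain in place of the ring, would shift the number further remains open.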